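A few compounds are considered here, and "the series" means these few. Any claim that something is new, unique, unknown or untested is made for them only; others in the source may bear on it.

Measured so far in an assay on cell membranes for displacement of a labelled ligand from adenosine receptor A3 (Homo sapiens), in the presence of a further agent that is not named here; a lower number here means a stronger inhibitor, a higher number a weaker inhibitor:
compound 1 `CC(=O)Nc1nc(-c2ccccc2)nc2nc(C)cn12`, 231 nM
compound 2 `CCC(=O)CNc1nc(-c2ccccc2)nc2nc(C)cn12`, which gives only a limit of the assay, > 10000 nM

Going by the values given here, compound 1 holds the only number in this assay; the other value shown is a limit, (the limit of > 10000 nM in this assay, at which 1 of the 2 values shown sits). Compound 2 differs from compound 1 by propanoylmethyl in place of acetyl on a nitrogen on an aromatic ring, and that step, an at least 43-fold higher number from compound 1 to compound 2 (1.63 log units; beyond the scatter), is the only measured one in the series.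

Compound 3 `CC(=O)Nc1nc(-c2ccccc2)nc2nc(-c3ccccc3)cn12` differs from compound 1 by phenyl in place of methyl on an aromatic carbon. Among the compounds with values here, the measured step concerns the acyl group on the nitrogen, not this ring carbon, so none of the measured steps bears on the change to compound 3. The expectation therefore rests on compound 1 alone, with a wide range and no clear direction. With nothing measured to guide it, the expected step is a 1.7-fold higher number from compound 1 to compound 3 (0.24 log units; within the scatter). Compound 3 is estimated at 400 nM, within 80 nM to 3000 nM.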

Compound 3, inhibition constant: 40 nM
Compound 3: the middle estimate sits 10-fold (1.00 log units) above what was measured, outside the stated range (below it).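

Moving from methyl to phenyl on the aromatic carbon of the five-membered ring, with the acetyl on the nitrogen kept, gives a stronger inhibitor in this assay (a 5.8-fold lower number from compound 1 to compound 3 (0.76 log units; beyond the scatter)). Going by these compounds alone, this is the first measured change at this carbon, and it shows that the position accepts a six-membered aromatic ring and that the number responds to what sits there, a response in the favourable direction, whereas the only earlier step, on the nitrogen, went the other way. Nothing shown here explains why phenyl outperforms methyl at this carbon.

A cyclohexyl group, a longer alkyl chain or a phenyl carrying a methoxy group or an amine at this carbon would show whether an aromatic ring is needed. Also open, on these data alone, is whether a different acyl group on the nitrogen, such as benzoyl, holds up with phenyl on this carbon.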